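Extending the chain beyond a short-lived carbonyl ester

This account rests on a few compounds, and the source may have more. Where it says the series, first, only, none or still open, it means among the compounds named here.

For the measured compounds named here, compound 2 `Cc1cn(C2CC(N=[N+]=[N-])C(COC(=O)OCCCN)O2)c(=O)[nH]c1=O` stands alone as the only plain number in an ADME assay on the whole organism (serum) with Homo sapiens as the target (on this read-out lower numbers stand for a shorter-lived compound and higher numbers for a longer-lived compound), at 0.133 h. Compound 1 `Cc1cn(C2CC(N=[N+]=[N-])C(COC(=O)NCCCO)O2)c(=O)[nH]c1=O` reaches a limit of the assay, > 48 h, as noted under (the limit of > 48 h in this assay, at which 1 of the 2 values shown sits). Going by the values given here, the one measured step, an at least 360-fold lower number from compound 1 to compound 2 (2.55 log units; beyond the scatter), changed the carbonyl side chain and fell far beyond the scatter. Compound 3 `Cc1cn(C2CC(N=[N+]=[N-])C(COC(=O)OCCCCCO)O2)c(=O)[nH]c1=O` differs from compound 2 by 2-hydroxyethyl in place of amino on a saturated chain carbon, three bonds along the chain from an oxygen next to a carbonyl group, keeping the oxygen next to the carbonyl. Among the compounds with values here, no measured step matches this change, so the expected step of a 2.3-fold higher number from compound 2 to compound 3 (0.35 log units; beyond the scatter) is modest and uncertain. Compound 3 is estimated at 0.3 h, between 0.08 h and 1.5 h.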

Compound 3, half-life: 0.267 h
The estimate for compound 3 lay 1.1-fold (0.05 log units) above the measured number; the measured number falls inside the stated range.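

Putting 2-hydroxyethyl in place of amino gave a 2.0-fold higher number from compound 2 to compound 3 (0.30 log units; within the scatter) in this assay, so a short-lived number here does not require the terminal amino group. With both chains ending in hydroxyl, the wide gap remains: an at least 170-fold lower number from compound 1 to compound 3 (2.25 log units; beyond the scatter). Compound 1 stands at a limit of the assay, > 48 h.

That step changes the atom on the carbonyl carbon and the chain length together. A (3-hydroxypropyl)oxy or a (5-hydroxypentyl)amino group on the carbonyl carbon would separate the two, and the compounds shown leave that open.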